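A few compounds are considered here, and "the series" means these few. Any claim that something is new, unique, unknown or untested is made for them only; others in the source may bear on it.

Compound 1, `COc1cc(-c2ccnc3c(-c4ccc(C)cc4)cnn23)cc(OC)c1OC`, gives in a functional assay on HCT-116 cells (Homo sapiens) for inhibition, read by CCK-8 assay, with a stated time of 48 h (a lower number here means a stronger inhibitor, a higher number a weaker inhibitor), a limit of the assay, > 10000 nM.
Compound 2, `COc1cc(-c2ccnc3cc(-c4ccc(C(C)(C)C)cc4)nn23)cc(OC)c1OC`, gives in this assay a limit of the assay, > 10000 nM.
Compound 3, `COc1cc(-c2ccnc3cc(-c4ccc(C(C)=O)cc4)nn23)cc(OC)c1OC`, gives in this assay 4390 nM.

Going by the values given here, compound 3 is thus the only member with a number; the other two sit at the limit of > 10000 nM in this assay, at which 2 of the 3 values shown sit. Compound 4, `COc1ccc(-c2cc3nccc(-c4cc(OC)c(OC)c(OC)c4)n3n2)cc1`, differs from compound 3 by methoxy in place of acetyl on an aromatic carbon. Among the compounds with values here, the one measured step at this position, an at least 2.2-fold lower number from compound 2 to compound 3 (0.35 log units; beyond the scatter), shows that a change of the group here can move the number at least modestly. Within the data shown here, no step from acetyl to methoxy has been measured, so the direction for compound 4 is open. Compound 4 is expected to give 7000 nM, within 2500 nM to 20000 nM, which means an estimated step of a 1.6-fold higher number from compound 3 to compound 4 (0.20 log units; within the scatter).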

Compound 4, half-maximal inhibitory concentration: 404 nM
Beside the measured number, compound 4's estimate is 17-fold (1.24 log units) above it; the measured number lies below the stated range.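

Methoxy in place of acetyl gives an 11-fold lower number from compound 3 to compound 4 (1.04 log units; beyond the scatter), which shows that this position can turn a weak inhibitor into a much stronger one in this assay, and not merely shift the number modestly. Methoxy in place of tert-butyl gives an at least 24-fold lower number from compound 2 to compound 4 (1.39 log units; beyond the scatter). That second step is only a bound, as compound 2 gives a limit of the assay and not a number: the limit of > 10000 nM in this assay, at which 2 of the 4 values shown sit.

On these data alone, it remains open whether an amine, a hydroxyl group or a longer chain such as ethoxy would match methoxy here. As far as these compounds go, whether the gain holds on other cell lines also stays unknown.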